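A few compounds are considered here, and "the series" means these few. Any claim that something is new, unique, unknown or untested is made for them only; others in the source may bear on it.

Measured so far:
compound 1 `Cc1cccc(NC(=O)c2c(O)c3cccnc3n(-c3ccccc3)c2=O)c1` gives 4.5%
compound 2 `Cc1ccccc1NC(=O)c1c(O)c2cccnc2n(-c2ccccc2)c1=O` gives 9.8%

Both numbers come from a functional assay on the whole organism for inhibition, with Rattus norvegicus as the target, read by cytopathic effect and paw edema, at a dose of 100 mg/kg by the oral route; on this read-out lower numbers stand for less inhibition and higher numbers for more inhibition at the one dose given (going by the name of the read-out). Compound 2 stands highest of the two, but its nearest neighbour, compound 1, sits only a number 5.3 percentage points higher from compound 1 to compound 2 (within the scatter) away, so the two cannot be told apart. Compound 3 `Cc1cnccc1NC(=O)c1c(O)c2cccnc2n(-c2ccccc2)c1=O` has not yet been measured. It differs from compound 2 in one place: 3-methylpyridin-4-yl in place of 2-methylphenyl on an amide-type nitrogen. The ring that leaves is one six-membered aromatic ring of carbon only; the ring that enters is one six-membered aromatic ring with 1 hetero atom and brings 1 hydrogen-bond acceptor. Among the compounds with values here, the only measured step, from compound 1 to compound 2, exchanged 2-methylphenyl for 3-methylphenyl and stayed within the scatter; no measured step exchanges a carbon-only ring for a ring with a hetero atom. The expectation for compound 3 is therefore no step beyond the scatter, a number 1.8 percentage points lower from compound 2 to compound 3 (within the scatter). Compound 3 is estimated at 8%, with a range from 0% to 22%.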

Compound 3, a percentage reported as inhibition, in the whole organism at one dose (the size of the read-out at that dose, not a potency): 8.8%
Compound 3: the middle estimate sits 0.8 percentage points below what was measured; low and high end bracket the measured number.
By their numbers in this assay, from the lowest: compounds 1, 3 and 2 (each within the scatter of the next).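

In this assay, 3-methylpyridin-4-yl in place of 2-methylphenyl on an amide-type nitrogen gives a number 1 percentage points lower from compound 2 to compound 3 (within the scatter) and, set against the other methylphenyl group, gives a number 4.3 percentage points higher from compound 1 to compound 3 (within the scatter) as well. Within the data shown here, these are the first steps here that exchange a carbon-only ring for a ring with a hetero atom, and they show that a ring nitrogen with its hydrogen-bond acceptor at this place leaves the numbers impossible to tell apart, so the three compounds cannot be ranked. Nothing measured here offers an explanation for this result.

On these data alone, whether an amine or a carboxylic acid on this ring would give a number beyond the scatter stays open. The same holds for a longer chain in place of the methyl group.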